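This account rests on a few compounds, and the source may have more. Where it says the series, first, only, none or still open, it means among the compounds named here.

Measured compounds in the series:

compound 1 `COc1cc2ncnc(NNC(=S)NC(=O)c3ccc(Cl)cc3)c2cc1OC` – 4590 nM
compound 2 `COc1ccccc1C(=O)NC(=S)NNc1ncnc2ccccc12` – > 50000 nM
compound 3 `O=C(NC(=S)NNc1ncnc2ccccc12)c1ccc(F)cc1` – 1870 nM

In a functional assay on KB cells (Homo sapiens) for cytotoxicity, read by MTT assay, with a stated time of 72 h (on this read-out higher numbers stand for weaker inhibition and lower numbers for stronger inhibition), compound 1 gives 4590 nM and stands at the highest of the two numbers reported. Its nearest neighbour is compound 3, which gives a lower number, 1870 nM. Compound 2 gives no number, only a limit, > 50000 nM. The value of compound 2 sits at the limit of > 50000 nM in this assay, at which 1 of the 3 values shown sits.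

Going by the values given here, the one step between measured compounds that differ in a single place is the exchange on the carbonyl carbon, which gives an at least 26-fold lower number from compound 2 to compound 3 (1.42 log units; beyond the scatter). That step bears on the present question only in that it shows the group on the carbonyl carbon can move the read-out strongly.

Compound 4 `COc1cc2ncnc(NNC(=S)NC(=O)c3ccc(C)cc3)c2cc1OC` differs from compound 1 by methyl in place of chloro on an aromatic carbon; cut one bond further out, the same difference reads 4-chlorophenyl to 4-methylphenyl. Among the compounds with values here, no measured pair shows chloro against methyl on this ring, so the expectation rests on the size of the group alone. A step of a 1.2-fold higher number from compound 1 to compound 4 (0.08 log units; within the scatter) is expected, within the scatter. For compound 4 the estimate in this assay is 5500 nM, with a range of 2000 nM to 16000 nM.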

Compound 4, half-maximal inhibitory concentration: 24200 nM
The estimate for compound 4 lay 4.4-fold (0.64 log units) below the measured number; measured number above the stated range.
By their numbers in this assay, from the lowest: compound 3; then compound 1; then compound 4. At a limit, above all of these: compound 2.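

In this assay, on the six-membered aromatic ring of carbon only, para to a large group, methyl in place of chloro gives a 5.3-fold higher number from compound 1 to compound 4 (0.72 log units; beyond the scatter), so this position responds to the exchange of one single-atom group for another, with the rest of compound 1 unchanged. The earlier single-place step, an at least 26-fold lower number from compound 2 to compound 3 (1.42 log units; beyond the scatter), replaced one whole substituted phenyl with another and could not show that so small a change at this one position would carry the read-out beyond the scatter. Both groups count 1 heavy atom, so that count does not account for the step, and nothing measured here gives it a cause.

It remains open how an amine, a carboxylic acid or a longer chain such as propyl would read at this position on the core of compound 1, so the compounds shown cannot tell whether chloro is the exception or methyl is. On these data alone, it also remains open whether methyl in place of chloro would give a similar step on the core of compound 3.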